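The source may hold more compounds than are shown below. What is called first, only, known or untested is meant among the compounds shown, and "the series" means these compounds.

Compound 1, `CCOC(=O)C[C@H]1[C@@H](O[Si](C)(C)C(C)(C)C)[C@H](n2cnc3c(NC(=O)Nc4ccccc4)ncnc32)O[C@@H]1COC(=O)NC`: 2.07 nM
Compound 2, `CNC(=O)NC[C@H]1O[C@@H](n2cnc3c(NC(=O)Nc4ccccc4)ncnc32)[C@H](O[Si](C)(C)C(C)(C)C)[C@@H]1CC(=O)N(C)OC`: 29 nM

In a functional assay on BT-549 cells (Homo sapiens) for antiproliferative activity (a lower number here means a stronger inhibitor of growth, a higher number a weaker inhibitor of growth), compound 1 gives 2.07 nM. Compound 2 stands highest of the two numbers; in this assay compound 2 gives 29 nM, and its nearest neighbour is compound 1, whose lower number lies beyond the scatter. Compound 3, `CCOC(=O)C[C@H]1[C@@H](O[Si](C)(C)C(C)(C)C)[C@H](n2cnc3c(NC(=O)Nc4ccccc4)ncnc32)O[C@@H]1CNC(=O)NC`, has not yet been measured. It differs from compound 2 in one place: ethoxy in place of methoxy(methyl)amino on a carbonyl carbon. Among the measured compounds shown here, the ethoxycarbonyl group that enters is the one carried by compound 1, which shows the lowest number, though compound 1 and compound 3 also differ elsewhere, so only their values can be set side by side. For the step from compound 2 to compound 3 a move toward a lower number, beyond the scatter, is expected, because compound 1 with the same group gives 2.07 nM. Compound 3 is therefore estimated at 6 nM, within a range of 2 nM to 20 nM, meaning a change of a 4.8-fold lower number from compound 2 to compound 3 (0.68 log units; beyond the scatter).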

Compound 3, concentration for 50% growth inhibition: > 100 nM
Compound 3: no number, only a limit; the forecaster's own chance of this, stated with the estimate: 2%; at least 16-fold (1.22 log units) between middle value and limit.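

In this assay compound 3 gives > 100 nM, a limit of the assay and not a number: the limit of > 100 nM in this assay, at which 1 of the 3 values shown sits. On a carbonyl carbon, ethoxy in place of methoxy(methyl)amino gives an at least 3.4-fold higher number from compound 2 to compound 3 (0.53 log units; beyond the scatter), so the ethoxycarbonyl group does not by itself bring the low number seen with compound 1. On a saturated chain carbon bound to a saturated ring carbon, (methylcarbamoyl)amino in place of (methylcarbamoyl)oxy gives an at least 48-fold higher number from compound 1 to compound 3 (1.68 log units; beyond the scatter), which shows that the outcome for ethoxy depends on this second place, something the first two compounds, differing in both places, could not separate.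

As far as these compounds go, how far compound 3 lies past its limit stays open, so both steps give only a minimum size. Also open, from the compounds shown here alone, is how a carboxylic acid or a propoxy group on the carbonyl carbon would read with either chain.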